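The source may report more compounds than this note shows. Statements on the series, on what has been measured and on what is new or still open speak of the compounds shown alone.

Measured so far:
compound 1, `Cn1nc2c(=O)n(CC3(O)CCN(Cc4ccc(-c5n[nH]c(=O)o5)cc4Cl)CC3)cnc2c1-c1ccc(CN)cc1`: 171 nM
compound 2, `Cn1nc2c(=O)n(CC3(O)CCN(Cc4ccc(-c5ccco5)cc4Cl)CC3)cnc2c1-c1ccc(CNC2CC2)cc1`: 54.1 nM

Both were tested in an assay on isolated protein for inhibition of ubiquitin carboxyl-terminal hydrolase 7 (Homo sapiens), with stated times of 30 min and 2 h; on this read-out lower numbers stand for stronger inhibition and higher numbers for weaker inhibition. Compound 1 has the higher of the two numbers; compound 2 sits a good way lower, beyond the usual scatter, though the two structures differ in more than one place, so no single change can be credited.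

Compound 3, `Cn1nc2c(=O)n(CC3(O)CCN(Cc4ccc(-c5cncs5)cc4Cl)CC3)cnc2c1-c1ccc(CN)cc1`, has not yet been measured. It differs from compound 1 at one spot: a group of 5 heavy atoms (3 carbon, 1 nitrogen, 1 sulfur; one five-membered aromatic ring with 2 hetero atoms) in place of a group of 6 heavy atoms (2 carbon, 2 nitrogen, 2 oxygen; one five-membered aromatic ring with 3 hetero atoms), on an aromatic carbon. Among the measured compounds shown here, nothing among the measured compounds shows what this particular exchange does, so the expectation rests on the general closeness of the two structures. Compound 3 is estimated to land near compound 1, with a step of a 1.2-fold higher number from compound 1 to compound 3 (0.07 log units; within the scatter) that is expected to stay within the scatter. The estimate for compound 3 in this assay is 200 nM, with a range from 60 nM to 700 nM.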

Compound 3, half-maximal inhibitory concentration: 117 nM
The estimate for compound 3 lay 1.7-fold (0.23 log units) above the measured number, within the range that was stated.
By their numbers in this assay, from the lowest: compound 2; then compounds 3 and 1 (each within the scatter of the next).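

In this assay the exchange at this aromatic carbon, para to a large group, gives a 1.5-fold lower number from compound 1 to compound 3 (0.16 log units; within the scatter) and so leaves the two rings indistinguishable. The 1,3-thiazol-5-yl group has 0 hydrogen-bond donors and the ring it replaces has 1 hydrogen-bond donor, so in this pair a donor on this ring is not needed to keep the number within the scatter. Nothing measured here explains why the two rings behave alike.

Compound 2 differs from compound 1 and compound 3 in more than one place, so what its own group at this position contributes cannot be separated from its other change. Going by these compounds, whether a non-ring group at this carbon, such as a carboxylic acid or an amine, would also leave the number within the scatter remains open.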